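Shrinking the Saturated Ring on Compound 1

The source may report more compounds than this note shows. Statements on the series, on what has been measured and on what is new or still open speak of the compounds shown alone.

Measured so far in an ADME assay on HUVEC cells (Homo sapiens) for antiproliferative activity, read by resazurin assay, with a stated time of 72 h; on this read-out lower numbers stand for stronger inhibition of growth and higher numbers for weaker inhibition of growth:
- compound 1 `O=C1C(N2CCCCC2)=NN(c2ccc(Cl)cc2)CN1c1ccccc1Cl` gives > 50 ug/mL, which is a limit of the assay and not a number.
- compound 2 `O=C1C(N2CCCCC2)=NN(c2ccccc2)CN1c1ccccc1Cl` gives 24.7 ug/mL.

Compound 1 therefore stands only at the limit (the limit of > 50 ug/mL in this assay, at which 1 of the 2 values shown sits), with no exact number. Among the measured compounds shown here, the one measured step, an at least 2.0-fold lower number from compound 1 to compound 2 (0.30 log units; that floor lies within the scatter), comes from hydrogen in place of chloro on an aromatic carbon, and its size lies within the scatter.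

The compound not yet measured is compound 3 `O=C1C(N2CCCC2)=NN(c2ccc(Cl)cc2)CN1c1ccccc1Cl`. It differs from compound 1 by pyrrolidin-1-yl in place of piperidin-1-yl on a carbon with a double bond to nitrogen. For the measured compounds named here, no measured step touches this part of the structure: the only measured step changes an aromatic substituent, not the saturated ring, so it gives no guide for the direction or size of the step from compound 1 to compound 3. Without a measured reference, no step beyond the scatter is expected in this assay. Compound 3 is estimated at 60 ug/mL, between 25 ug/mL and 150 ug/mL, which means an expected step that the limit leaves unreadable from compound 1 to compound 3. Because compound 1 sits at the limit (the limit of > 50 ug/mL in this assay, at which 1 of the 2 values shown sits), compound 3 is expected quite possibly to report only a limit too.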

Compound 3, concentration for 50% growth inhibition: 18.9 ug/mL
Compound 3: the middle estimate sits 3.2-fold (0.50 log units) above what was measured, and the stated range ends above it.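

In this assay, the saturated ring on the carbon with a double bond to nitrogen turns out to matter: pyrrolidin-1-yl in place of piperidin-1-yl gives an at least 2.6-fold lower number from compound 1 to compound 3 (0.42 log units; beyond the scatter). Among the compounds shown here, the only earlier step changed an aromatic substituent, so this is the first evidence that growth inhibition responds to this part of the structure, and compound 3 gives 18.9 ug/mL while still carrying the 4-chlorophenyl group of compound 1. Compound 1 stands at a limit and not at a number, so this step is only a floor and the real gap may be wider: the limit of > 50 ug/mL in this assay, at which 1 of the 3 values shown sits.

The compounds shown leave open whether a still smaller ring such as azetidin-1-yl, a ring with a second hetero atom such as morpholin-4-yl or piperazin-1-yl, or an open-chain diethylamino group would give a lower or a higher number on this carbon. Also open, as far as these compounds go, is whether the same exchange of piperidin-1-yl for pyrrolidin-1-yl would lower the number on the core of compound 2, which has no chloro on that aromatic ring.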